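This account rests on a few compounds, and the source may have more. Where it says the series, first, only, none or still open, it means among the compounds named here.

Series measured in an ADME assay on HEK293 cells (Homo sapiens) for cytotoxicity, read by MTT assay, with a stated time of 24 h; a lower number here means a stronger inhibitor, a higher number a weaker inhibitor
- Compound 1 `CN(C)CCCNc1nc2cc([N+](=O)[O-])ccc2nc1NCc1ccccc1C(F)(F)F` gives 24.7 ug/mL
- Compound 2 `CN(C)CCCNc1nc2cc([N+](=O)[O-])ccc2nc1NCc1ccccc1Br` gives 51.9 ug/mL
- Compound 3 `COc1ccccc1CNc1nc2ccc([N+](=O)[O-])cc2nc1NCCCN(C)C` gives 36.1 ug/mL

Compound 3 stands within the scatter of both compound 1 and compound 2, though the step of a 2.1-fold higher number from compound 1 to compound 2 (0.32 log units; beyond the scatter) separates those two. Next comes compound 4 `CN(C)CCCNc1nc2cc([N+](=O)[O-])ccc2nc1NCc1cccc(C(F)(F)F)c1`, with the change (3-(trifluoromethyl)phenyl in place of 2-methoxyphenyl on a saturated chain carbon bound to a nitrogen on an aromatic ring), that is, 3-(trifluoromethyl)phenyl in place of 2-methoxyphenyl on a saturated chain carbon bound to a nitrogen on an aromatic ring. The closest measured exchange, methoxy in place of trifluoromethyl on an aromatic carbon, gave a 1.5-fold higher number from compound 1 to compound 3 (0.16 log units; within the scatter) and, read in reverse, points only weakly to a lower number. Within the data shown here, no measured compound carries 3-(trifluoromethyl)phenyl, so no step beyond the scatter is expected. The expected step is a 1.2-fold lower number from compound 3 to compound 4 (0.08 log units; within the scatter), a small one. Compound 4 is estimated at 30 ug/mL, with an expected range from 15 ug/mL to 60 ug/mL.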

Compound 4, half-maximal inhibitory concentration: 7.99 ug/mL
Beside the measured number, compound 4's estimate is 3.8-fold (0.57 log units) above it; measured number below the stated range.
By their numbers in this assay, from the lowest: compound 4; then compounds 1, 3 and 2 (each within the scatter of the next, the first and the last beyond it).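

In this assay, 3-(trifluoromethyl)phenyl in place of 2-(trifluoromethyl)phenyl gives a 3.1-fold lower number from compound 1 to compound 4 (0.49 log units; beyond the scatter) (the first sign that the group's location on the phenyl ring matters here, not only its presence). The same entering group gives a 4.5-fold lower number from compound 3 to compound 4 (0.65 log units; beyond the scatter) and a 6.5-fold lower number from compound 2 to compound 4 (0.81 log units; beyond the scatter) (so compound 4 has the lowest number of the four). Nothing on hand explains these steps.

As far as these compounds go, it remains open whether the lower number is specific to trifluoromethyl, which 3-methoxyphenyl or 3-bromophenyl would test. A 4-(trifluoromethyl)phenyl group is also untested among the compounds shown.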